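The source may report more compounds than this note shows. Statements on the series, on what has been measured and on what is new or still open speak of the compounds shown alone.

Working notes on the hydrazide series. Compound 1 `COc1ccc(C(=O)NNC(=O)c2ccc3[nH]c(-c4ccc([N+](=O)[O-])o4)nc3c2)cc1OC` is the reference point; in an ADME assay on NIH3T3 cells (Mus musculus) for inhibition, read by sulforhodamine B assay, with a stated time of 48 h (on this read-out higher numbers stand for weaker inhibition of growth and lower numbers for stronger inhibition of growth), compound 1 gives 31.3 ug/mL. Compound 2 `O=C(NNC(=O)c1cc2ccccc2cc1O)c1ccc2[nH]c(-c3ccc([N+](=O)[O-])s3)nc2c1`, a close relative with a different heteroaromatic ring on the shared core and a different acid part, gives in this assay a value of 31.3 ug/mL. On these numbers compound 1 stands level with compound 2 at the digits given; the two values lie within the usual scatter of the read-out, so no difference between them can be claimed.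

Compound 3 `COc1cc(C(=O)NNC(=O)c2ccc3[nH]c(-c4ccc([N+](=O)[O-])o4)nc3c2)cc(OC)c1OC` has not yet been measured. It differs from compound 1 by methoxy in place of hydrogen on an aromatic carbon. For the measured compounds named here, no step between two measured compounds involves a change of this kind, so the size of the step cannot be read off from the data; the expectation rests on compound 1 alone. The step from compound 1 is expected to be a 1.0-fold lower number from compound 1 to compound 3 (0.00 log units; within the scatter), that is, no change beyond the scatter. Compound 3 is therefore estimated at 31 ug/mL in this assay, with a range from 12 ug/mL to 75 ug/mL.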

Compound 3, concentration for 50% growth inhibition: 31.3 ug/mL
Estimate against measurement, compound 3: 1.0-fold (0.00 log units) below; low and high end bracket the measured number.
By their numbers in this assay, from the lowest: compounds 1, 2 and 3 (each within the scatter of the next).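

In this assay methoxy in place of hydrogen on an aromatic carbon gives no change at the digits printed from compound 1 to compound 3 (within the scatter). For the compounds shown here, this is the only step so far that can be read at a single place, and it shows that this carbon, ortho to a methoxy group and meta to a large group, takes a further methoxy with no shift in the read-out beyond the scatter. Nothing at hand bears on why the read-out stays level here.

As far as these compounds go, whether the read-out also stays level with an amine, a carboxylic acid or a longer alkoxy chain on this carbon remains open. Also open, from the compounds shown here alone, is whether methoxy in place of hydrogen gives the same result with the other heteroaromatic ring and acid part of compound 2.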